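The source may hold more compounds than are shown below. What is called first, only, known or untested is meant among the compounds shown, and "the series" means these compounds.

In a functional assay on MGC-803 cells (Homo sapiens) for inhibition, read by sulforhodamine B assay, with a stated time of 72 h, tested at 10 uM (a lower number here means less inhibition, a higher number more inhibition at the concentration tested (going by the name of the read-out)), the three measured compounds gave these numbers:
compound 1, `Cc1cc(Nc2ccc(C(=O)/C=C/c3cccc(Br)n3)cc2)n2nc(SCc3ccccc3)nc2n1`: 90.2%
compound 2, `Cc1cc(Nc2ccc(C(=O)/C=C/c3cccc(Br)n3)cc2)n2nc(SCc3ccc([N+](=O)[O-])cc3)nc2n1`: 91.6%
compound 3, `Cc1cc(Nc2ccc(C(=O)/C=C/c3cccc(Br)n3)cc2)n2nc(SCc3nc4ccccc4[nH]3)nc2n1`: 94.4%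

Compound 3 holds the highest number of the three, yet both of its steps, a number 4.2 percentage points higher from compound 1 to compound 3 (within the scatter) and a number 2.8 percentage points higher from compound 2 to compound 3 (within the scatter), lie within the scatter, as does a number 1.4 percentage points higher from compound 1 to compound 2 (within the scatter). All three measured steps change only the group on the saturated chain carbon bound to the sulfur, and none of them moved the read-out beyond the scatter.

Compound 4, `Cc1cc(Nc2ccc(N3CCN(C)CC3)cc2)n2nc(SCc3nc4ccccc4[nH]3)nc2n1`, differs from compound 3 in a different part of the molecule: 4-methylpiperazin-1-yl in place of (2-(6-bromopyridin-2-yl)ethenyl)carbonyl on an aromatic carbon. The group that leaves carries the two double bonds outside aromatic rings and the six-membered aromatic ring with one hetero atom; the group that enters is a six-membered non-aromatic ring with two hetero atoms. For the measured compounds named here, no measured step touches this part of the molecule, so the measured steps give no direct guide to the size or direction of the change here. Going by the values given here, with the three measured compounds all at high inhibition and no comparable step to lean on, compound 4 is expected at 45%, inside a wide range from 10% to 85%. The step this estimate means, a number 49.4 percentage points lower from compound 3 to compound 4 (beyond the scatter), is thus expected to be a fall beyond the scatter, but the expectation rests on little.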

Compound 4, a percentage reported as inhibition, at one concentration (the size of the read-out at that concentration, not a potency): 78.1%
Compound 4: the middle estimate sits 33.1 percentage points below what was measured; the measured number falls inside the stated range.
By their numbers in this assay, from the lowest: compound 4; then compounds 1, 2 and 3 (each within the scatter of the next).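

In this assay replacing (2-(6-bromopyridin-2-yl)ethenyl)carbonyl with 4-methylpiperazin-1-yl gives a number 16.3 percentage points lower from compound 3 to compound 4 (beyond the scatter) and is the only step shown that lies beyond the scatter. The read-out therefore responds to this place on the aromatic ring, para to a large group, whereas the changes on the saturated chain carbon bound to the sulfur among compounds 1, 2 and 3 did not move it beyond the scatter. Even without the bromopyridine ring, compound 4 gives 78.1% at the single concentration tested, although nothing available explains the drop.

The swap replaces the carbonyl, the carbon-carbon double bond and the ring together, so it remains open which of these parts accounts for the step. A phenyl in place of the 6-bromopyridin-2-yl, or a morpholin-4-yl in place of the 4-methylpiperazin-1-yl, would help separate them.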